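The source may hold more compounds than are shown below. What is called first, only, known or untested is meant among the compounds shown, and "the series" means these compounds.

Of the compounds shown here, two have so far been measured in a functional assay for antagonist activity at Alpha-1A adrenergic receptor (Oryctolagus cuniculus); on this read-out higher numbers stand for weaker binding and lower numbers for tighter binding. Compound 1, with the structure `COc1ccccc1N1CCN(CCCOc2ccccc2C(=O)N(C)C)CC1`, gives in this assay a value of 3.98 nM. Compound 2, with the structure `CN(C)C(=O)c1cccnc1NCCCN1CCN(c2ccccc2O)CC1`, gives in this assay a value of 5.01 nM. Compound 2 thus carries the higher of the two numbers, but the gap to compound 1 is only a small one and lies within the usual scatter of this kind of measurement, so the two compounds cannot be told apart on these data.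

The step considered here leads from compound 2 to compound 3, whose structure is `CN(C)C(=O)c1cccnc1NCCCN1CCN(c2ccccc2OCC2CC2)CC1`. The change is cyclopropylmethyl in place of hydrogen on an oxygen on an aromatic ring; seen one bond further out, a hydroxy group becomes a cyclopropylmethoxy group. Going by the values given here, no pair of measured compounds shows this change on its own, so there is no directly comparable step to lean on. Compound 3 is expected to stay close to compound 2, with at most a modest move toward a higher number, the step from compound 2 to compound 3 estimated as a 1.4-fold higher number from compound 2 to compound 3 (0.15 log units; within the scatter). Compound 3 is accordingly estimated to give 7 nM in this assay, within a range from 2 nM to 25 nM.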

Compound 3, dissociation constant: 0.159 nM
Estimate against measurement, compound 3: 44-fold (1.64 log units) above; the whole stated range lies above it.
By their numbers in this assay, from the lowest: compound 3; then compounds 1 and 2 (each within the scatter of the next).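

In this assay, going by these compounds alone, putting cyclopropylmethyl in place of hydrogen on the oxygen on the aromatic ring gives a 32-fold lower number from compound 2 to compound 3 (1.50 log units; beyond the scatter), a large step well beyond the scatter, and it is the first change that can be read in one place alone. It shows that this oxygen need not carry a free hydrogen to keep a low number on this read-out, and that a group of four carbons with a three-membered ring at this place goes with much tighter binding than the hydroxy group of compound 2, whereas compounds 1 and 2 differ in more than one place and so said nothing about this position by themselves. Nothing in the data at hand accounts for the size of this step.

The compounds shown leave open whether the three-membered ring itself matters, or whether an open group such as ethoxy or a longer chain such as butoxy on the same oxygen would go the same way. They also leave open whether the oxygen is needed at all, for instance whether an amine at this place would give a comparable number.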